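Changing the Base on Compound 2

A few compounds are considered here, and "the series" means these few. Any claim that something is new, unique, unknown or untested is made for them only; others in the source may bear on it.

In a functional assay on MT4 cells (Homo sapiens) for cytotoxicity (a lower number here means that less compound is tolerated, a higher number that more compound is tolerated), compound 2 (`CC(C)(C)[Si](C)(C)OC[C@H]1O[C@@H](n2cnc3ncnc(O)c32)[C@H](O[Si](C)(C)C(C)(C)C)[C@]12OS(=O)(=O)C=C2N`) gives 15000 nM, the lower of the two exact numbers, and compound 3 (`COc1ccc(C(Nc2ncnc3c2ncn3[C@@H]2O[C@H](CO[Si](C)(C)C(C)(C)C)[C@@]3(OS(=O)(=O)C=C3N)[C@H]2O[Si](C)(C)C(C)(C)C)(c2ccccc2)c2ccccc2)cc1`) gives 192000 nM. Compound 1 (`CC(C)(C)[Si](C)(C)OC[C@H]1O[C@@H](n2cnc3ncn([C@@H]4O[C@H](CO[Si](C)(C)C(C)(C)C)[C@@]5(OS(=O)(=O)C=C5N)[C@H]4O[Si](C)(C)C(C)(C)C)c3c2=O)[C@H](O[Si](C)(C)C(C)(C)C)[C@]12OS(=O)(=O)C=C2N`) reaches > 150000 nM, which is a limit of the assay and not a number. Compound 4 (`CC(C)(C)[Si](C)(C)OC[C@H]1O[C@@H](n2c(=O)[nH]c(=O)c3[nH]cnc32)[C@H](O[Si](C)(C)C(C)(C)C)[C@]12OS(=O)(=O)C=C2N`) has not yet been measured. It differs in one place, on a saturated ring carbon: a group of 11 heavy atoms (5 carbon, 4 nitrogen, 2 oxygen; one five-membered aromatic ring with 2 hetero atoms, one six-membered aromatic ring with 2 hetero atoms) in place of a group of 10 heavy atoms (5 carbon, 4 nitrogen, 1 oxygen; one five-membered aromatic ring with 2 hetero atoms, one six-membered aromatic ring with 2 hetero atoms), on a saturated ring carbon. Everything else is shared with compound 2, so its 15000 nM is the natural starting point. For the measured compounds named here, no step clearly beyond the usual scatter is expected, and the estimate is a 1.7-fold higher number from compound 2 to compound 4 (0.22 log units; within the scatter). For compound 4 the estimated value is 25000 nM, with an expected range of 9000 nM to 90000 nM.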

Compound 4, half-maximal cytotoxic concentration: 14000 nM
Estimate against measurement, compound 4: 1.8-fold (0.25 log units) above, within the range that was stated.
By their numbers in this assay, from the lowest: compounds 4 and 2 (each within the scatter of the next); then compound 3.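

In this assay, for the compounds shown here, this is the first comparison in which only the group on the saturated ring carbon next to the ring oxygen differs, and the step is a 1.1-fold lower number from compound 2 to compound 4 (0.03 log units; within the scatter). Here, a group with one more oxygen and 2 double bonds outside aromatic rings is tolerated on the same scale as the group it replaces. Neither compound 2 nor compound 4 stands at a limit of the assay: the limit of > 150000 nM in this assay, at which 1 of the 4 values shown sits.

The compounds shown leave open whether a single-ring base such as uracil at this carbon would fall on the same scale. They also leave open whether this holds once the silyl ether groups are replaced by free hydroxyl groups.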